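The compounds below may be only part of what the source reports. "The series", "measured", "known", "first", "only" and "open" are said of these compounds alone.

Compound 1 `COc1cc(NC(C)CCCNC(=O)NNC(=O)Nc2cc(C(F)(F)F)cc(C(F)(F)F)c2)c2ncccc2c1` and compound 2 `COc1cc(NC(C)CCCNC(=O)Nc2ccc(O)cc2)c2ncccc2c1` share one core. In a functional assay on L1210 cells (Mus musculus) for inhibition, read by MTT assay, with a stated time of 72 h (a higher number here means a weaker inhibitor, a lower number a stronger inhibitor), compound 1 gives 18000 nM, and compound 2 gives 21000 nM; these two numbers lie within the scatter of each other, so neither stands apart. Compound 3 `COc1cc(NC(C)CCCNC(=O)NNC(=O)Nc2cccc(C(F)(F)F)c2)c2ncccc2c1` keeps the core of compound 1 but differs in one place: hydrogen in place of trifluoromethyl on an aromatic carbon. Within the data shown here, no pair of measured compounds shows what such a change does, so the step is expected to be small, without a clear direction beyond the scatter. Compound 3 is therefore estimated at 25000 nM, between 9000 nM and 70000 nM. That estimate is expected to mean a step of a 1.4-fold higher number from compound 1 to compound 3 (0.14 log units; within the scatter).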

Compound 3, half-maximal inhibitory concentration: 4000 nM
For compound 3 the middle estimate is 6.3-fold (0.80 log units) above the measured one, outside the stated range (below it).
By their numbers in this assay, from the lowest: compound 3; then compounds 1 and 2 (each within the scatter of the next).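

In this assay the aromatic ring proves sensitive at this position: hydrogen in place of trifluoromethyl gives a 4.5-fold lower number from compound 1 to compound 3 (0.65 log units; beyond the scatter) and so yields a stronger inhibitor, with the other trifluoromethyl group kept. The earlier compounds shown here could not show this, since they offered no single-place change to read. Nothing at hand gives a reason for this step. Still open, going by these compounds, is whether losing the remaining trifluoromethyl group would shift the number further. Also open, on these data alone, is how a chlorine atom or an amine would compare with hydrogen at the same place.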